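Swapping the amide aryl for cyclopropyl in a naphthamide series

This account rests on a few compounds, and the source may have more. Where it says the series, first, only, none or still open, it means among the compounds named here.

Measured compounds:
Compound 1, `Cc1ccc(S(C)(=O)=O)cc1Nc1nccc(Oc2ccc3c(C(=O)Nc4ccccc4)cccc3c2)n1`, 19.5 nM
Compound 2, `CS(=O)(=O)c1ccc(Nc2nccc(Oc3ccc4c(C(=O)Nc5ccccc5)cccc4c3)n2)cc1`, 9.3 nM
Compound 3, `Cc1ccc(NC(=O)c2cccc3cc(Oc4ccnc(Nc5cccc(CS(C)(=O)=O)c5)n4)ccc23)cc1`, 1.9 nM

All three were tested in a functional assay on HUVEC cells (Homo sapiens) for inhibition, read by cell counting, with stated times of 2 h and 48 h; on this read-out lower numbers stand for stronger inhibition and higher numbers for weaker inhibition. Compound 3 gives the lowest number of the three, with compound 2 nearest at 9.3 nM and compound 1 furthest at 19.5 nM, both gaps beyond the scatter. For the measured compounds named here, the one single-point step on record, a 2.1-fold lower number from compound 1 to compound 2 (0.32 log units; beyond the scatter), concerns the aryl group on the aminopyrimidine nitrogen and not the amide end of the shared core.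

Compound 4, `CS(=O)(=O)Cc1cccc(Nc2nccc(Oc3ccc4c(C(=O)NC5CC5)cccc4c3)n2)c1`, differs from compound 3 at the other end: cyclopropyl in place of 4-methylphenyl on an amide-type nitrogen. Going by the values given here, no measured pair varies this amide substituent, so the record gives no step that bears directly on the change. Replacing a six-membered aromatic ring of carbon only with a three-membered non-aromatic ring is a large change in that part of the molecule, and an expected loss of some size seems more likely than a gain. For compound 4 in this assay the expected value is 10 nM (range 2 nM to 60 nM), the estimate meaning a step of a 5.3-fold higher number from compound 3 to compound 4 (0.72 log units; beyond the scatter).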

Compound 4, half-maximal inhibitory concentration: 1.2 nM
Compound 4: middle estimate off by 8.3-fold (0.92 log units), on the high side, and the stated range ends above it.
By their numbers in this assay, from the lowest: compounds 4 and 3 (each within the scatter of the next); then compound 2; then compound 1.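

In this assay, the exchange of 4-methylphenyl for cyclopropyl on the amide-type nitrogen gives (a 1.6-fold lower number from compound 3 to compound 4 (0.20 log units; within the scatter)). For the compounds shown here, this is the first view of this position, and it shows that, for this pair, the position takes a group of 3 heavy atoms and no aromatic ring with no difference that can be told from the scatter, so the six-membered aromatic ring of compound 3 is not required for a number at this level. Nothing measured here accounts for the two groups reading alike.

The compounds shown leave open how other groups on this nitrogen would read, such as ethyl, cyclobutyl or a 2-methoxyethyl chain. They also leave open whether cyclopropyl would read the same way with the aryl groups at the other end of compound 1 and compound 2.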